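This account rests on a few compounds, and the source may have more. Where it says the series, first, only, none or still open, it means among the compounds named here.

Three amides sharing one core have been read in a functional assay on WM164 cells (Homo sapiens) for antiproliferative activity, read by sulforhodamine B assay, with a stated time of 48 h; on this read-out lower numbers stand for stronger inhibition and higher numbers for weaker inhibition: compound 1 (`CCCCCCCCCCCCNC(=O)[C@@H]1CSC(c2ccc(NC(C)=O)cc2)N1`) gives 1200 nM, compound 2 (`CCCCCCCCCCCCCCCNC(=O)[C@@H]1CSC(c2ccc(NC(C)=O)cc2)N1`) gives 1000 nM, and compound 3 (`CCCCCCCCCCCCCCCCNC(=O)[C@@H]1CSC(c2ccc(NC(C)=O)cc2)N1`) gives 600 nM. Compound 3 does not separate from either of the others, since a 2.0-fold lower number from compound 1 to compound 3 (0.30 log units; within the scatter) and a 1.7-fold lower number from compound 2 to compound 3 (0.22 log units; within the scatter) both lie within the scatter, as does a 1.2-fold lower number from compound 1 to compound 2 (0.08 log units; within the scatter). Compound 4 (`CCCCCCCCCCCCCCCCCNC(=O)[C@@H]1CSC(c2ccc(NC(C)=O)cc2)N1`) differs from compound 3 by methyl in place of hydrogen on a saturated chain carbon, ten or more bonds along the chain from an amide-type nitrogen. For the measured compounds named here, the same methyl change, a 1.7-fold lower number from compound 2 to compound 3 (0.22 log units; within the scatter), is the closest precedent, and the larger additions on this chain also stayed within the scatter. An estimated no change at the digits printed from compound 3 to compound 4 (within the scatter) is therefore expected, with no step beyond the scatter in this assay. Compound 4 is estimated at 600 nM, with an expected range of 280 nM to 1200 nM.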

Compound 4, half-maximal inhibitory concentration: 2400 nM
Compound 4: the middle estimate sits 4.0-fold (0.60 log units) below what was measured; measured number above the stated range.
By their numbers in this assay, from the lowest: compounds 3, 2, 1 and 4 (each within the scatter of the next, the first and the last beyond it).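

In this assay, adding methyl on a saturated chain carbon is no longer silent: it gives a 4.0-fold higher number from compound 3 to compound 4 (0.60 log units; beyond the scatter). The ethyl difference also passes the scatter, at a 2.4-fold higher number from compound 2 to compound 4 (0.38 log units; beyond the scatter), whereas the pentyl difference does not, at a 2.0-fold higher number from compound 1 to compound 4 (0.30 log units; within the scatter), so chain length at this position matters for some pairs but not all.

On these data alone, how a longer chain, or an amine or carboxylic acid at the chain end, would read remains open. No available data give a reason for these steps.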